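The compounds below may be only part of what the source reports. "The series", "measured", "known", "first", "only" and "open" are said of these compounds alone.

Compound 1 `COc1ccc([C@H]2CC(=O)N(c3cccc(N)c3C)C2)cc1OC1CCCC1`, compound 2 `COc1ccc([C@H]2CC(=O)N(c3ccccc3C)C2)cc1OC1CCCC1` and compound 3 `COc1ccc([C@H]2CC(=O)N(c3cccc([S+](C)[O-])c3)C2)cc1OC1CCCC1` share one core and differ only in the aromatic ring carried by the amide-type nitrogen. In a functional assay on HEK293 cells (Homo sapiens) for cytotoxicity (on this read-out higher numbers stand for lower toxicity in this test and lower numbers for higher toxicity in this test), compound 1 gives no number but only a limit of the assay, > 10000 nM. In this assay compound 2 likewise stops at a limit, > 10000 nM. In this assay compound 3 also stops at a limit, > 10000 nM. Because every value shown sits at the limit of > 10000 nM in this assay, at which 3 of the 3 values shown sit, none of the steps between the three compounds can be read in size or direction: a step that the two limits leave unreadable from compound 1 to compound 2, a step that the two limits leave unreadable from compound 1 to compound 3 and a step that the two limits leave unreadable from compound 2 to compound 3. Compound 3 therefore stands at the same limit as the other two, without a number that would place it higher or lower.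

Compound 4 `COc1ccc([C@H]2CC(=O)N(c3cccc(NS(=O)(=O)c4c(Br)nn(C)c4Cl)c3)C2)cc1OC1CCCC1` differs from compound 3 by a group of 12 heavy atoms (4 carbon, 3 nitrogen, 2 oxygen, 1 sulfur, 1 chlorine, 1 bromine; one five-membered aromatic ring with 2 hetero atoms) in place of a group of 3 heavy atoms (1 carbon, 1 oxygen, 1 sulfur; no ring), on an aromatic carbon. The three unreadable steps are the only ones that bear on this change, and they give no size in either direction to expect in this assay. The expectation for compound 4 is that it again reaches the limit, and its estimated value is 10000 nM, with a range from 3000 nM to 40000 nM. The step this implies is expected to stay within the scatter, a number no higher from compound 3 to compound 4 (the limit leaves the size open).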

Compound 4, half-maximal cytotoxic concentration: > 10000 nM
Compound 4: only a limit was reported (the forecaster's own chance of this, stated with the estimate: 70%); the middle value lies on the limit itself.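

In this assay compound 4 gives no number, only a limit, > 10000 nM. The step between compound 3 and compound 4 therefore cannot be read in size or direction, because both stop at the same limit: the limit of > 10000 nM in this assay, at which 4 of the 4 values shown sit.

Going by these compounds, at what concentration any of compounds 1 to 4 would become toxic to these cells, and how they would rank, stays open.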